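The compounds below may be only part of what the source reports. "The series", "measured", "known", "first", "only" and "open" are said of these compounds alone.

Compound 1 `CN(C[C@H]1Cc2c(cccc2N2CCN(C3CC3)CC2)CN1)[C@H]1CCCc2cccnc21` is one of two compounds that have been tested in a functional assay on CCRF-CEM cells for agonist activity at C-X-C chemokine receptor type 4 (Homo sapiens), read by calcium flux, with a stated time of 25 min; on this read-out higher numbers stand for an effect only at larger amounts of compound and lower numbers for an effect already at smaller amounts. In this assay compound 1 gives > 30000 nM, which is a limit of the assay rather than a number. Compound 2 `CCN(C[C@H]1Cc2c(cccc2N2CCNCC2)CN1)[C@H]1CCCc2cccnc21` shares the same core but carries a different group at one end. In this assay compound 2 gives > 30000 nM, again a limit and not a number. Both values sit at the same point, as shown by the limit of > 30000 nM in this assay, at which 2 of the 2 values shown sit, so compound 1 cannot be placed above or below compound 2 on these numbers.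

Compound 3 `C[C@@H]1CN(c2cccc3c2C[C@H](CN(C)[C@H]2CCCc4cccnc42)NC3)C[C@H](C)N1C` has not yet been measured. It differs from compound 1 in one place: 3,4,5-trimethylpiperazin-1-yl in place of 4-cyclopropylpiperazin-1-yl on an aromatic carbon. Going by the values given here, no step between two measured compounds is available to show how large a change of this kind tends to be. With both measured compounds resting at the limit, the step from compound 1 to compound 3 is expected to be none beyond the scatter, expressed as a number no higher from compound 1 to compound 3 (the limit leaves the size open). Compound 3 is therefore estimated to give 30000 nM in this assay, with a range from 10000 nM to 100000 nM, and most likely again only a limit.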

Compound 3, half-maximal effective concentration: > 30000 nM
Compound 3: only a limit was reported; the forecaster's own chance of this, stated with the estimate: 85%; the middle value lies on the limit itself.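

No step from compound 1 to compound 3 can be read in this assay, since both results are limits of the assay and not numbers: the limit of > 30000 nM in this assay, at which 3 of the 3 values shown sit.

The compounds shown leave open how compound 1, compound 2 and compound 3 rank against one another, and what change, if any, 3,4,5-trimethylpiperazin-1-yl brings in place of 4-cyclopropylpiperazin-1-yl.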